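This account rests on a few compounds, and the source may have more. Where it says the series, first, only, none or still open, it means among the compounds named here.

Compound 1, `NS(=O)(=O)CSc1nnc(Br)n1Cc1ccc(Br)c2ccccc12`, gives in an assay on HEK293 cells for inhibition of solute carrier family 22 member 12 (Homo sapiens) (on this read-out lower numbers stand for stronger inhibition and higher numbers for weaker inhibition), a value of 365000 nM.
Compound 2, `O=S(=O)(CSc1nnc(Br)n1Cc1ccc(Br)c2ccccc12)Nc1ccc(Cl)nc1`, gives in this assay a value of 1940 nM.

For the measured compounds named here, compound 2 stands lowest of the two numbers; its only neighbour is compound 1, and the step of a 190-fold lower number from compound 1 to compound 2 (2.27 log units; beyond the scatter) is large and beyond the scatter. Compound 3, `O=S(=O)(CSc1nnc(Br)n1Cc1ccc(Br)c2ccccc12)Nc1cccnc1Br`, differs from compound 2 by 2-bromopyridin-3-yl in place of 6-chloropyridin-3-yl on a sulfonamide nitrogen. Going by the values given here, no measured step compares two such groups on that nitrogen; the one recorded step concerns adding a group where hydrogen stood, not exchanging one group for another. For compound 3 no step beyond the scatter is therefore expected, and a 1.3-fold higher number from compound 2 to compound 3 (0.11 log units; within the scatter) is estimated as roughly no movement. Compound 3 is expected to give 2500 nM, within 800 nM to 8000 nM.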

Compound 3, half-maximal inhibitory concentration: 280 nM
For compound 3 the middle estimate is 8.9-fold (0.95 log units) above the measured one; the whole stated range lies above it.
By their numbers in this assay, from the lowest: compound 3; then compound 2; then compound 1.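

The sulfonamide nitrogen responds not only to whether a group is present but also to which group it carries: in this assay, exchanging 6-chloropyridin-3-yl for 2-bromopyridin-3-yl, two groups with the same count of heavy atoms, gives a 6.9-fold lower number from compound 2 to compound 3 (0.84 log units; beyond the scatter). Against the plain sulfonamide, the new group gives a 1300-fold lower number from compound 1 to compound 3 (3.12 log units; beyond the scatter). Nothing available here offers a reason for these steps. The exchange alters both the halogen and its place on the ring, and the compounds shown do not separate the two. A 2-chloropyridin-3-yl group on the same nitrogen would be needed to separate them.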